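A cyclohexyl ether replaces a hydroxylated bicycle

This account rests on a few compounds, and the source may have more. Where it says the series, first, only, none or still open, it means among the compounds named here.

This set concerns an ADME assay for permeability; on this read-out lower numbers stand for lower permeability and higher numbers for higher permeability. Compound 1 `CNC(=O)c1cc(C(=O)N[C@H]2[C@@H]3C[C@H](O)C[C@@H]32)n([C@@H](C)c2cccc(Cl)c2)n1` gives 333 nm/s in this assay. Compound 2 `CNC(=O)c1cc(C(=O)N[C@H]2[C@@H]3C[C@@H](O)C[C@@H]32)n([C@@H](C)c2ccccc2)n1`, which carries a phenyl without the chlorine, gives 61 nm/s in this assay, the lower of the two numbers, with compound 1 standing higher by a gap beyond the usual scatter. Compound 3 `CNC(=O)c1cc(C(=O)NC2CC2)n(Cc2ccccc2)n1` is known in this assay only as a limit of the assay, > 80 nm/s. That limit is the one described as the limit of > 80 nm/s in this assay, at which 1 of the 3 values shown sits, so no exact number exists for compound 3.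

The unmeasured compound 4 `CNC(=O)c1cc(C(=O)N[C@H]2CC[C@H](OC)CC2)n([C@@H](C)c2ccccc2)n1` differs from compound 2 in one place: a group of 8 heavy atoms (7 carbon, 1 oxygen; one six-membered non-aromatic ring of carbon only) in place of a group of 7 heavy atoms (6 carbon, 1 oxygen; one three-membered non-aromatic ring of carbon only, one five-membered non-aromatic ring of carbon only), on an amide-type nitrogen. The incoming 4-methoxycyclohexyl sits on the amide-type nitrogen that otherwise neighbours only a carbonyl carbon.

Among the measured compounds shown here, no measured pair shows this kind of change, so the expectation rests on the spread already seen. A rise beyond the scatter is expected, the step of a 4.1-fold higher number from compound 2 to compound 4 (0.61 log units; beyond the scatter) pointing upward from compound 2. Compound 4 is therefore estimated at about 250 nm/s in this assay, somewhere between 100 nm/s and 600 nm/s.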

Compound 4, apparent permeability: 360 nm/s
The estimate for compound 4 lay 1.4-fold (0.16 log units) below the measured number, and the stated range covers the measured number.
By their numbers in this assay, from the lowest: compound 2; then compounds 1 and 4 (each within the scatter of the next).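

Among the compounds shown here, the single change on the amide-type nitrogen gives a 5.9-fold higher number from compound 2 to compound 4 (0.77 log units; beyond the scatter) in this assay, the first measured step at this position. With the rest of compound 2 kept, the read-out therefore responds to what sits on this nitrogen, and a hydroxylated bicycle is not needed for the higher number. The swap changes the ring system, goes from 1 hydrogen-bond donor to 0 and alters the stereocentres all at once, and nothing measured here gives a cause for the step.

Whether the ring or the methoxy group accounts for the step stays open, and a plain cyclohexyl or a hydroxycyclohexyl on the same nitrogen would separate the two. As far as these compounds go, how an aminocyclohexyl or a longer chain at this place would read in this assay also stays open.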